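A few compounds are considered here, and "the series" means these few. Any claim that something is new, unique, unknown or untested is made for them only; others in the source may bear on it.

Working notes on the series.

Going by the values given here, compound 1 `COc1ccc(/C=C/C(=O)Nc2cc(C(=O)c3cc(OC)c(OC)c(OC)c3)ccc2OC)cc1` gives 12800 nM in a functional assay on DU-145 cells (Homo sapiens) for cytotoxicity, read by MTT assay, with a stated time of 72 h (a higher number here means a weaker inhibitor, a lower number a stronger inhibitor), the highest of the three numbers known so far; its steps to the two other measured compounds both lie beyond the scatter. Compound 2 `COc1ccc(C(=O)c2cc(OC)c(OC)c(OC)c2)cc1NC(=O)/C=C/c1ccc(F)cc1` gives 3900 nM and compound 3 `COc1ccc(C(=O)c2cc(OC)c(OC)c(OC)c2)cc1NC(=O)/C=C/c1ccc(C(F)(F)F)cc1` gives 4300 nM. The step of a 3.3-fold lower number from compound 1 to compound 2 (0.52 log units; beyond the scatter) and the step of a 3.0-fold lower number from compound 1 to compound 3 (0.47 log units; beyond the scatter) are of similar size, while the step of a 1.1-fold higher number from compound 2 to compound 3 (0.04 log units; within the scatter) is within the scatter.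

Compound 4 `COc1ccc(C(=O)c2cc(OC)c(OC)c(OC)c2)cc1NC(=O)/C=C/c1cccc(OC(F)(F)F)c1` differs from compound 1 by 3-(trifluoromethoxy)phenyl in place of 4-methoxyphenyl on a double-bonded chain carbon bound to a double-bonded chain carbon. The two steps from compound 1 bear on this change: both exchange the methoxy on the aromatic carbon for a fluorine-bearing group and both lower the number by a modest amount. Among the compounds with values here, compound 4 also moves the substituent to a different place on that phenyl, for which no measured pair exists. The expectation is therefore a modest lowering, with added uncertainty: compound 4 is expected to give 4500 nM, in the range 2000 nM to 10000 nM, a step of a 2.8-fold lower number from compound 1 to compound 4 (0.45 log units; beyond the scatter).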

Compound 4, half-maximal inhibitory concentration: 10200 nM
For compound 4 the middle estimate is 2.3-fold (0.36 log units) below the measured one, outside the stated range (above it).
By their numbers in this assay, from the lowest: compounds 2 and 3 (each within the scatter of the next); then compounds 4 and 1 (each within the scatter of the next).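

Placing 3-(trifluoromethoxy)phenyl in place of 4-methoxyphenyl on a double-bonded chain carbon bound to a double-bonded chain carbon gives a 1.3-fold lower number from compound 1 to compound 4 (0.10 log units; within the scatter), so a fluorine-bearing group on this phenyl does not by itself bring the lowering seen with compound 2 and compound 3. The same position therefore separates the fluorine-bearing groups from one another, with a 2.4-fold higher number from compound 3 to compound 4 (0.38 log units; beyond the scatter) and a 2.6-fold higher number from compound 2 to compound 4 (0.42 log units; beyond the scatter). No evidence bearing on this result is available.

Compound 4 changes both the group and its place on the phenyl, so the compounds shown cannot separate the effect of the group from that of its place. From the compounds shown here alone, how an amine or a carboxylic acid on this phenyl would read in this assay also remains open.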